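This account rests on a few compounds, and the source may have more. Where it says the series, first, only, none or still open, it means among the compounds named here.

Measured in a functional assay on HCT-116 cells (Homo sapiens) for inhibition, read by MTT assay, with a stated time of 72 h; on this read-out lower numbers stand for stronger inhibition of growth and higher numbers for weaker inhibition of growth:
compound 1 `CNC(=O)/C=C/c1ccncc1-c1ccc2ccccc2c1` gives 6550 nM;
compound 2 `CNC(=O)/C=C/c1ccncc1-c1ccc2cc[nH]c2c1` gives 10400 nM;
compound 3 `CCOC(=O)/C=C/c1ccncc1-c1ccc2ccccc2c1` gives 910 nM.

Compound 1 and compound 2 carry different cores; the difference between the two cores is not broken down here, and their values in this assay lie within the usual scatter of each other. Compound 3 differs from compound 1 by ethoxy in place of methylamino on a carbonyl carbon, a change that gave a 7.2-fold lower number from compound 1 to compound 3 (0.86 log units; beyond the scatter). Compound 4 `CCOC(=O)/C=C/c1ccncc1-c1ccc2cc[nH]c2c1`, not yet measured, differs from compound 2 by ethoxy in place of methylamino on a carbonyl carbon, the same change at the same place, now on the core of compound 2. Among the compounds with values here, a step of similar size is expected, a 6.9-fold lower number from compound 2 to compound 4 (0.84 log units; beyond the scatter), resting on the single measured instance a 7.2-fold lower number from compound 1 to compound 3 (0.86 log units; beyond the scatter). On these data alone, whether that step carries over to the other core is untested. Compound 4 is therefore estimated at 1500 nM, expected between 500 nM and 4500 nM.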

Compound 4, concentration for 50% growth inhibition: 2140 nM
For compound 4 the middle estimate is 1.4-fold (0.15 log units) below the measured one; the range from low to high includes it.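

In this assay ethoxy in place of methylamino on a carbonyl carbon also gives a lower number on the second core (a 4.9-fold lower number from compound 2 to compound 4 (0.69 log units; beyond the scatter)), and the two steps agree: the same change on two cores in this assay, a 7.2-fold lower number (0.86 log units; beyond the scatter) from compound 1 to compound 3 and a 4.9-fold lower number (0.69 log units; beyond the scatter) from compound 2 to compound 4, 1.5-fold (0.17 log units) apart, within the scatter of two such steps. The change therefore carries over between the two cores shown, with a similar step on each. Two instances do not show that it will hold on any further core, and they do not tell what in the change produces the step.

Open, on these data alone, is whether the step is specific to ethoxy or also appears with methoxy, a longer alkoxy chain or a carboxylic acid on the same carbonyl carbon. Also open, as far as these compounds go, is how a primary amide or a dimethylamino group on that carbon compares with methylamino.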